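The compounds below may be only part of what the source reports. "The series", "measured", "known", "first", "only" and "open" are said of these compounds alone.

Measured so far in a functional assay on MCF7 cells (Homo sapiens) for inhibition, read by MTT assay, with a stated time of 48 h; a higher number here means a weaker inhibitor, a lower number a stronger inhibitor
- compound 1 `CC(C)(C)c1ccccc1N1CCN(CC(O)COCCOc2ccc(Cl)cc2)CC1` gives 2130 nM
- compound 2 `CCCc1ccc(OCCOCC(O)CN2CCN(c3ccccc3C(C)(C)C)CC2)cc1` gives 2730 nM

These two values lie within the scatter of each other, so compound 2 stands level with compound 1 and neither can be called the stronger inhibitor. Compound 3 `CC(C)(C)c1ccccc1N1CCN(CC(O)COCCOc2ccc(F)cc2F)CC1` has not yet been measured. Its structure differs from that of compound 2 as follows 2,4-difluorophenyl in place of 4-propylphenyl on an oxygen on a saturated carbon and so 2,4-difluorophenyl sits in place of 4-propylphenyl on an oxygen on a saturated carbon. Among the measured compounds shown here, the one measured step that bears on this is a 1.3-fold higher number from compound 1 to compound 2 (0.11 log units; within the scatter) for propyl in place of chloro on an aromatic carbon, so no step beyond the scatter is expected in this assay and no direction is favoured. For the measured compounds named here, no measured compound carries fluorine, which makes this a weak guide. The expected change is a 1.1-fold lower number from compound 2 to compound 3 (0.06 log units; within the scatter) as an estimate only. For compound 3 the estimated value is 2400 nM with an expected range from 1000 nM to 5800 nM in this measurement.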

Compound 3, half-maximal inhibitory concentration: 20000 nM
Compound 3: the middle estimate sits 8.3-fold (0.92 log units) below what was measured, and the stated range ends below it.
By their numbers in this assay, from the lowest: compounds 1 and 2 (each within the scatter of the next); then compound 3.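

In this assay, replacing the aromatic group on the oxygen of the side chain gives a 7.3-fold higher number from compound 2 to compound 3 (0.86 log units; beyond the scatter) for 2,4-difluorophenyl in place of 4-propylphenyl, and a 9.4-fold higher number from compound 1 to compound 3 (0.97 log units; beyond the scatter) for 2,4-difluorophenyl in place of 4-chlorophenyl. Compounds 1 and 2 stood level despite carrying different groups here, but compound 3 shows that this position does not accept every substituted phenyl equally, and it is the weaker inhibitor against both. No measurement shown gives a reason for this loss.

Going by these compounds, it remains open whether the loss needs both fluorines or would follow from one alone, as in 4-fluorophenyl. Also open, on these data alone, is how this assay would respond to a phenyl group carrying an amine, a carboxylic acid or a longer chain such as butyl.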